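This account rests on a few compounds, and the source may have more. Where it says the series, first, only, none or still open, it means among the compounds named here.

In a functional assay on MCF7 cells (Homo sapiens) for inhibition, read by sulforhodamine B assay (a higher number here means a weaker inhibitor of growth, a lower number a stronger inhibitor of growth), compound 1 (`c1ccc(-c2ccc(-c3ccc(-c4nc5ccccc5[nH]4)cc3)cc2)cc1`) gives 39200 nM and compound 2 (`CN(C)c1ccc(-c2ccc(-c3ccc(-c4nc5ccccc5[nH]4)cc3)cc2)cc1`) gives 41200 nM. Compound 3 (`Oc1cccc2[nH]c(-c3ccc(-c4ccc(-c5ccccc5)cc4)cc3)nc12`) gives 2200 nM, the lowest of the three numbers. Its difference from compound 1 is hydroxy in place of hydrogen on an aromatic carbon, and the step is large: an 18-fold lower number from compound 1 to compound 3 (1.25 log units; beyond the scatter).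

Compound 4 (`COc1ccc(-c2ccc(-c3ccc(-c4nc5c(O)cccc5[nH]4)cc3)cc2)cc1OC`) keeps that hydroxy, so this large step offers no direct guide. Among the compounds with values here, its one change from compound 3 is 3,4-dimethoxyphenyl in place of phenyl on an aromatic carbon. Within the data shown here, no measured pair makes this exact swap. The closest guide is dimethylamino in place of hydrogen on that same phenyl, which gave a 1.1-fold higher number from compound 1 to compound 2 (0.02 log units; within the scatter). That is a single example with a different group and without the hydroxy, so it supports only a cautious expectation of no step beyond the scatter in this assay.

The estimated step is a 1.2-fold higher number from compound 3 to compound 4 (0.07 log units; within the scatter). The expected value for compound 4 is 2600 nM, with an estimated range from 800 nM to 8500 nM.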

Compound 4, concentration for 50% growth inhibition: 190 nM
Estimate against measurement, compound 4: 14-fold (1.14 log units) above, outside the stated range (below it).
By their numbers in this assay, from the lowest: compound 4; then compound 3; then compounds 1 and 2 (each within the scatter of the next).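

In this assay, 3,4-dimethoxyphenyl in place of phenyl, on an aromatic carbon para to a large group, gives a 12-fold lower number from compound 3 to compound 4 (1.06 log units; beyond the scatter), so a change at this position can shift the number strongly when the hydroxy is present. The earlier change at this position, dimethylamino in place of hydrogen, gave only a 1.1-fold higher number from compound 1 to compound 2 (0.02 log units; within the scatter) in compounds without the hydroxy, so this position is not insensitive to every change. Nothing available explains the size of the new step.

As far as these compounds go, it remains open whether 3,4-dimethoxyphenyl would give a similar step without the hydroxy, and whether both methoxy groups are needed or one would be enough. It is also unclear how groups of another kind at this position, such as an amine or a carboxylic acid, would compare.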